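The source may hold more compounds than are shown below. What is called first, only, known or untested is meant among the compounds shown, and "the series" means these compounds.

Compound 1 `COc1cc(C2CC(c3ccccc3)=NN2C(=O)OCc2ccccc2)cc(OC)c1OC` and compound 2 `COc1ccc(C2=NN(C(=O)OCc3ccccc3)C(c3cc(OC)c(OC)c(OC)c3)C2)cc1` share one core. In a functional assay on HeLa cells (Homo sapiens) for antiproliferative activity, read by MTT assay, with a stated time of 48 h (on this read-out higher numbers stand for weaker inhibition of growth and lower numbers for stronger inhibition of growth), compound 1 gives only a limit of the assay, > 10000 nM. Compound 2 likewise gives only a limit, > 10000 nM. The change between them is methoxy in place of hydrogen on an aromatic carbon, and the step that the two limits leave unreadable from compound 1 to compound 2 cannot be read because both values sit at the limit of > 10000 nM in this assay, at which 2 of the 3 values shown sit. Compound 3 `COC(=O)N1N=C(c2ccccc2)CC1c1ccc(OC)c(OC)c1` has another core; the difference between the two cores is not broken down here. In this assay compound 3 gives 5480 nM. Compound 4 `COC(=O)N1N=C(c2ccccc2)CC1c1cc(OC)c(OC)cc1OC` differs from compound 3 by methoxy in place of hydrogen on an aromatic carbon, the same kind of change as before, though here the place is ortho to a large group, meta to a methoxy group and para to a methoxy group, rather than para to a large group. Since the earlier step has no readable size, the expectation rests on compound 3 and its 5480 nM. For compound 4 a step of a 1.1-fold higher number from compound 3 to compound 4 (0.04 log units; within the scatter) is expected. Compound 4 is thus estimated at 6000 nM, with a range from 2000 nM to 20000 nM.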

Compound 4, concentration for 50% growth inhibition: 2470 nM
Compound 4: the middle estimate sits 2.4-fold (0.39 log units) above what was measured; the measured number falls inside the stated range.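

In this assay, methoxy in place of hydrogen on an aromatic carbon gives a 2.2-fold lower number from compound 3 to compound 4 (0.35 log units; beyond the scatter), so on the core of compound 3 this change, ortho to a large group, goes with modestly stronger inhibition of growth. On the core of compound 1 the same kind of change stands at a different place, and its step cannot be read because both values there are limits of the assay: the limit of > 10000 nM in this assay, at which 2 of the 4 values shown sit. Nothing shown therefore tells whether the change carries from one core to the other, since the only readable step comes from a single pair.

The compounds shown leave open whether this step depends on where the methoxy sits on the ring. They also leave open whether another group in that place, such as an amine, a carboxylic acid or a longer chain, would give a similar step.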